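The compounds below may be only part of what the source reports. "The series", "measured", "known", "first", "only" and "open" are said of these compounds alone.

Three compounds share one core and a seven-carbon chain from an oxygen on an aromatic ring to a charged nitrogen. Compound 1 `Cc1cc(-n2cc(C(=O)Nc3cc(F)cc(F)c3)c(=O)c3ccc(N(C)C)nc32)ccc1OCCCCCCC[N+]12CCN(CC1)CC2` and compound 2 `Cc1ccc(-n2cc(C(=O)Nc3cc(F)cc(F)c3)c(=O)c3ccc(N(C)C)nc32)cc1OCCCCCCC[N+]12CCN(CC1)CC2` are built from the same atoms joined differently; the difference between their two cores is not broken down here. In an assay on LX2 cells for inhibition of COL1A1 promoter (Homo sapiens), read by a luciferase reporter, with a stated time of 24 h, tested at 20 uM (a lower number here means a weaker effect, a higher number a stronger effect of the compound at the concentration tested), compound 1 gives 10.6% and compound 2 gives 5.07%, two numbers within the usual scatter of each other. Compound 3 `Cc1cc(-n2cc(C(=O)Nc3cc(F)cc(F)c3)c(=O)c3ccc(N(C)C)nc32)ccc1OCCCCCCC[N+]1(C)CCCC1` differs from compound 1 by a group of 6 heavy atoms (5 carbon, 1 nitrogen; one five-membered non-aromatic ring with 1 hetero atom) in place of a group of 8 heavy atoms (6 carbon, 2 nitrogen; 2 six-membered non-aromatic rings with 2 hetero atoms each), on a saturated chain carbon, seven bonds along the chain from an oxygen on an aromatic ring, and in this assay compound 3 gives 26.1%, a step of a number 15.5 percentage points higher from compound 1 to compound 3 (beyond the scatter).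

Compound 4 `Cc1ccc(-n2cc(C(=O)Nc3cc(F)cc(F)c3)c(=O)c3ccc(N(C)C)nc32)cc1OCCCCCCC[N+]1(C)CCCC1` differs from compound 2 by a group of 6 heavy atoms (5 carbon, 1 nitrogen; one five-membered non-aromatic ring with 1 hetero atom) in place of a group of 8 heavy atoms (6 carbon, 2 nitrogen; 2 six-membered non-aromatic rings with 2 hetero atoms each), on a saturated chain carbon, seven bonds along the chain from an oxygen on an aromatic ring. The place is the same word for word as in the change from compound 1 to compound 3, so it is the same change made on the other core. Going by the values given here, a step of the same size is expected from compound 2 to compound 4 in this assay, namely a number 13.9 percentage points higher from compound 2 to compound 4 (beyond the scatter), because the only measured instance, a number 15.5 percentage points higher from compound 1 to compound 3 (beyond the scatter), is the sole guide available. For compound 4 the expected value in this assay is 19%, with the likely range 5% to 33%.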

Compound 4, a percentage reported as inhibition, at one concentration (the size of the read-out at that concentration, not a potency): 12.7%
The estimate for compound 4 lay 6.3 percentage points above the measured number, and the stated range covers the measured number.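

Carried to the other core, the exchange of the two-ring group for the five-membered ring group in this assay gives a number 7.6 percentage points higher from compound 2 to compound 4 (within the scatter) and agrees with the earlier step as far as this read-out can tell: the same change on two cores in this assay, a number 15.5 percentage points higher (beyond the scatter) from compound 1 to compound 3 and a number 7.6 percentage points higher (within the scatter) from compound 2 to compound 4, 7.9 percentage points apart, within the scatter of two such steps. The two pairs are therefore compatible with the change carrying over from one core to the other, and both steps are printed in the same direction. This does not show that the change has a real effect on the second core, where the step taken alone is not separated from the scatter, and two pairs at one concentration say nothing about potency or about any other core.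

All the compounds shown keep the same chain and end in a charged nitrogen, so a shorter or longer chain, or a plain tertiary amine such as morpholine at its end, remains open. Also open, on these data alone, is whether the same exchange would hold at other concentrations of the compounds.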